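Phenyl in place of butyl on a selenocyanate carbamate

The source may hold more compounds than are shown below. What is called first, only, known or untested is meant among the compounds shown, and "the series" means these compounds.

Two related compounds have been tested in a functional assay on HT-29 cells (Homo sapiens) for cytotoxicity, read by MTT assay, with a stated time of 72 h; a lower number here means a stronger inhibitor of growth, a higher number a weaker inhibitor of growth. Compound 1 `O=C(Nc1ccc([Se][Se]c2ccc(NC(=O)OCc3ccccc3)cc2)cc1)OCc1ccccc1` gives 35400 nM in this assay, and compound 2 `CCCCOC(=O)Nc1ccc([Se]C#N)cc1` gives 31300 nM. The two numbers lie within the usual scatter of each other, so neither compound can be said to inhibit growth more strongly than the other; compound 2 simply stands at one end of this narrow pair.

The next compound, compound 3 `N#C[Se]c1ccc(NC(=O)Oc2ccccc2)cc1`, keeps the whole of compound 2 except for one change: phenyl in place of butyl on an oxygen next to a carbonyl group. The carbamate and the selenocyanate-bearing core stay as they are.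

Within the data shown here, no measured pair in this set shows what such an exchange does to the concentration for total growth inhibition, so there is no step to lean on. With only compound 1 and compound 2 to go by, and those two within scatter of each other, the expectation for compound 3 is a step from compound 2 that stays within the scatter, estimated as a 1.0-fold lower number from compound 2 to compound 3 (0.02 log units; within the scatter). Compound 3 is therefore estimated to give 30000 nM in this assay, with a range from 12000 nM to 75000 nM.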

Compound 3, concentration for total growth inhibition: 41700 nM
Compound 3: middle estimate off by 1.4-fold (0.14 log units), on the low side; measured number inside the range.
By their numbers in this assay, from the lowest: compounds 2, 1 and 3 (each within the scatter of the next).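

Among these compounds, measured in this assay on an oxygen next to a carbonyl group, phenyl in place of butyl gives a 1.3-fold higher number from compound 2 to compound 3 (0.12 log units; within the scatter) and is the first step read at this place. An open chain can thus give way to a six-membered aromatic ring of carbon only without moving the concentration for total growth inhibition beyond the usual scatter, so compound 2 and compound 3 cannot be told apart here. This holds for this one pair only, and nothing measured alongside these numbers helps to interpret the step.

The compounds shown leave open whether any group on this oxygen, such as a longer chain or a chain ending in an amine or a carboxylic acid, would produce a step beyond the scatter. It also remains open whether phenyl in place of butyl would give a similar result on the core of compound 1, because no pair shown tests the exchange there.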